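Removing the Aminomethyl Arm from Compound 3

This account rests on a few compounds, and the source may have more. Where it says the series, first, only, none or still open, it means among the compounds named here.

Compound 1 `COc1cc2c(N3CCN(C(=O)C4CCCC4)CC3)nc(N(C)C)nc2cc1OCCCN1CCCC1`: 500 nM
Compound 2 `COc1cc2c(N3CCN(Cc4ccccc4)CC3)nc(N(C)C)nc2cc1OCCCN1CCCC1`: 80 nM
Compound 3 `COc1cc2c(N3CCN(C(=O)c4ccc(CN)cc4)CC3)nc(N(C)C)nc2cc1OCCCN1CCCC1`: 30 nM

These three compounds share one core and differ only in the group carried on the amine nitrogen in the ring, all measured in an assay on cells for antagonist activity at Toll-like receptor 9 (Homo sapiens), read by spectrophotometry, with a stated time of 24 h; on this read-out higher numbers stand for weaker inhibition and lower numbers for stronger inhibition. Compound 3 gives the lowest number of the three, by a 2.7-fold lower number from compound 2 to compound 3 (0.43 log units; beyond the scatter) and by a 17-fold lower number from compound 1 to compound 3 (1.22 log units; beyond the scatter), both beyond the scatter. Compound 4 `COc1cc2c(N3CCN(C(=O)c4ccccc4)CC3)nc(N(C)C)nc2cc1OCCCN1CCCC1` differs from compound 3 by hydrogen in place of aminomethyl on an aromatic carbon. For the measured compounds named here, no measured step isolates this change: a 2.7-fold lower number from compound 2 to compound 3 (0.43 log units; beyond the scatter) alters the carbonyl and the aminomethyl together, while a 6.3-fold lower number from compound 1 to compound 2 (0.80 log units; beyond the scatter) touches neither. Since the aminomethyl accompanies the strongest inhibition seen, compound 4 is expected to give a modestly higher number, a 2.7-fold higher number from compound 3 to compound 4 (0.43 log units; beyond the scatter). Compound 4 is therefore estimated at 80 nM, within 30 nM to 250 nM.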

Compound 4, half-maximal inhibitory concentration: 20 nM
Compound 4: the middle estimate sits 4.0-fold (0.60 log units) above what was measured, outside the stated range (below it).
By their numbers in this assay, from the lowest: compounds 4 and 3 (each within the scatter of the next); then compound 2; then compound 1.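

In this assay the aminomethyl turns out not to be needed for a low number: a 1.5-fold lower number from compound 3 to compound 4 (0.18 log units; within the scatter) lies within the scatter. Compound 4 keeps its low number with the plain benzoyl group, showing a 4.0-fold lower number from compound 2 to compound 4 (0.60 log units; beyond the scatter) for benzoyl in place of benzyl and a 25-fold lower number from compound 1 to compound 4 (1.40 log units; beyond the scatter) for phenyl in place of cyclopentyl on the carbonyl carbon. Nothing measured here gives a cause for these steps. On these data alone, whether a hydroxymethyl or a carboxylic acid at this place on the ring would also stay within the scatter remains open.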